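The source may hold more compounds than are shown below. What is called first, only, known or untested is meant among the compounds shown, and "the series" means these compounds.

Compound 1 `COc1ccc(/C=C/C(=O)c2ccccc2NC(=O)NS(=O)(=O)c2ccc(C)cc2)c(OC)c1` gives 16 ug/mL in an ADME assay on the whole organism for cytotoxicity, with Artemia salina as the target, with a stated time of 24 h; on this read-out lower numbers stand for an effect already at smaller amounts and higher numbers for an effect only at larger amounts of compound.
Compound 2 `CCOc1cc(/C=C/C(=O)c2ccccc2NC(=O)NS(=O)(=O)c2ccc(C)cc2)ccc1O` gives 19.2 ug/mL in this assay.
Compound 3 `COc1cc(/C=C/C(=O)c2ccccc2NC(=O)NS(=O)(=O)c2ccc(C)cc2)ccc1O` gives 17.8 ug/mL in this assay.

Among these three numbers compound 3 stands second highest; its nearest neighbour is compound 2, and the step of a 1.1-fold lower number from compound 2 to compound 3 (0.03 log units; within the scatter) lies within the scatter, as does the step of a 1.1-fold higher number from compound 1 to compound 3 (0.05 log units; within the scatter) from the furthest compound. Compound 4 `C=CCOc1ccc(/C=C/C(=O)c2ccccc2NC(=O)NS(=O)(=O)c2ccc(C)cc2)cc1` differs from compound 3 by 4-(allyloxy)phenyl in place of 4-hydroxy-3-methoxyphenyl on a double-bonded chain carbon bound to a double-bonded chain carbon. Within the data shown here, the steps that bear on this change all alter the aryl group at the same place on the chain: a 1.2-fold higher number from compound 1 to compound 2 (0.08 log units; within the scatter), a 1.1-fold higher number from compound 1 to compound 3 (0.05 log units; within the scatter) and a 1.1-fold lower number from compound 2 to compound 3 (0.03 log units; within the scatter) each stayed within the scatter. Another variation of that aryl group is therefore expected to produce no step beyond the scatter in this assay. Compound 4 is estimated to give 17 ug/mL, with a range from 9 ug/mL to 32 ug/mL. This expected result corresponds to a step of a 1.0-fold lower number from compound 3 to compound 4 (0.02 log units; within the scatter) that stays within the scatter.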

Compound 4, concentration for half-maximal effect: 6.11 ug/mL
For compound 4 the middle estimate is 2.8-fold (0.44 log units) above the measured one; measured number outside the range, below it.
By their numbers in this assay, from the lowest: compound 4; then compounds 1, 3 and 2 (each within the scatter of the next).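

In this assay this place on the chain proves sensitive after all: 4-(allyloxy)phenyl gives a 2.9-fold lower number from compound 3 to compound 4 (0.46 log units; beyond the scatter), a 3.1-fold lower number from compound 2 to compound 4 (0.50 log units; beyond the scatter) and a 2.6-fold lower number from compound 1 to compound 4 (0.42 log units; beyond the scatter), whereas the earlier aryl groups stayed within the scatter of one another. Loss of the hydroxy group alone does not set compound 4 apart, as compound 1 also has none and still sits with compound 2 and compound 3. No measurement here explains the change. On these data alone, it remains open whether a saturated propoxy group at this place would match the allyloxy group, and how an amine or a carboxylic acid there would read.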